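Methyl for Acetyl on a Phenol Oxygen: Cytotoxicity Outlook

The source may hold more compounds than are shown below. What is called first, only, known or untested is meant among the compounds shown, and "the series" means these compounds.

Compound 1, `CC(=O)Oc1ccc(O)c(C[C@]2(C)[C@@H](C)CC[C@]3(C)C(C)=CCC[C@@H]23)c1`: > 27300 nM
Compound 2, `CC(=O)Oc1ccc(OC(C)=O)c(C[C@]2(C)[C@@H](C)CC[C@]3(C)C(C)=CCC[C@@H]23)c1`: > 24400 nM

Both measurements come from an ADME assay on CHO-K1 cells (Cricetulus griseus) for cytotoxicity; on this read-out lower numbers stand for stronger inhibition and higher numbers for weaker inhibition. For compound 1 the value > 27300 nM is a limit of the assay and not a number. For compound 2 the value > 24400 nM is likewise a limit. Going by the values given here, the only measured step, a step that the two limits leave unreadable from compound 1 to compound 2, therefore cannot be read, since both of its ends are limits (the limit of > 27300 nM in this assay, at which 1 of the 2 values shown sits, and (the limit of > 24400 nM in this assay, at which 1 of the 2 values shown sits)).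

Compound 3, `COc1ccc(O)c(C[C@]2(C)[C@@H](C)CC[C@]3(C)C(C)=CCC[C@@H]23)c1`, differs from compound 1 by methyl in place of acetyl on an oxygen on an aromatic ring. Among the compounds with values here, no measured step bears on this change, and compound 1 itself stands only at a limit in this assay. Compound 3 is expected to show a step that the limit leaves unreadable from compound 1 to compound 3, which means staying close to where compound 1 sits, most likely again as a limit rather than a number. For compound 3 the estimate is 30000 nM, with a range from 10000 nM to 100000 nM.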

Compound 3, half-maximal inhibitory concentration: > 29600 nM
Compound 3 ended at the assay's limit; the forecaster's own chance of this, stated with the estimate: 70%; the middle value is on the limit's open side.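

In this assay compound 3 gives > 29600 nM, a limit of the assay and not a number. Going by these compounds alone, compound 1 also stands at a limit, so no step between compound 1 and compound 3 can be read. The compounds shown leave open whether methyl or acetyl on this oxygen makes any difference.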